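Swapping Trifluoromethyl for Fluoro: What to Expect

A few compounds are considered here, and "the series" means these few. Any claim that something is new, unique, unknown or untested is made for them only; others in the source may bear on it.

Three compounds sharing one core have been tested in a functional assay on the whole organism (strain Swiss) with Mus musculus as the target, in the maximal electroshock model, with a stated time of 0.25 h, at a dose of 300 mg/kg by the intraperitoneal route; a higher number here means a stronger effect of the compound at the dose given, a lower number a weaker effect:

Compound 1, `COc1cccc(N2CCN(C(=O)C(C)N3C(=O)CCC3=O)CC2)c1`, gives 75%.
Compound 2, `CC(C(=O)N1CCN(c2ccc(Cl)cc2)CC1)N1C(=O)CCC1=O`, gives 100%.
Compound 3, `CC(C(=O)N1CCN(c2ccc(C(F)(F)F)cc2)CC1)N1C(=O)CCC1=O`, gives 25%.

Compound 3 stands lowest of the three in this assay, with compound 1 the nearest and compound 2 the furthest, both gaps beyond the scatter. Compound 4, `CC(C(=O)N1CCN(c2ccc(F)cc2)CC1)N1C(=O)CCC1=O`, has not yet been measured. It differs from compound 3 in one place: fluoro in place of trifluoromethyl on an aromatic carbon. Within the data shown here, the step that bears most on this is the one leading into compound 3: a number 75 percentage points lower from compound 2 to compound 3 (beyond the scatter). That step put a trifluoromethyl group where a chloro group had been, and the activity fell a long way. Compound 4 removes the trifluoromethyl group again and sets a fluoro group, another halogen, in its place. The other step, a number 25 percentage points higher from compound 1 to compound 2 (beyond the scatter), changed the group and the ring pattern together and says less here, but it shows that the chloro compound carried the highest value seen. A rise beyond the scatter is therefore expected in this assay, though not necessarily all the way back to the top. For compound 4 the estimated value is 75%, within 25% to 100%. This corresponds to an expected step of a number 50 percentage points higher from compound 3 to compound 4 (beyond the scatter).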

Compound 4, a percentage reported as activity, at one dose (the size of the read-out at that dose, not a potency): 100%
Compound 4: the middle estimate sits 25 percentage points below what was measured, and the stated range covers the measured number.
By their numbers in this assay, from the lowest: compound 3; then compound 1; then compounds 2 and 4 (each within the scatter of the next).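

In this assay, replacing trifluoromethyl with a single fluoro on this aromatic carbon gives a number 75 percentage points higher from compound 3 to compound 4 (beyond the scatter), so the low number of compound 3 is not shared by every fluorine-bearing group at this place. Fluoro and chloro stand level here, with no change at the digits printed from compound 2 to compound 4 (within the scatter), which makes trifluoromethyl the only one of the three groups tried at this position to give a low number. The comparison with the methoxy compound gives a number 25 percentage points higher from compound 1 to compound 4 (beyond the scatter), but that step changes both the group and where it sits on the ring, so it cannot separate the effect of one from the other.

On these data alone, whether a methyl group, a nitrile or a plain hydrogen on this aromatic carbon would match the two halogens or fall toward trifluoromethyl remains open, as does whether fluoro and chloro would still match at a lower dose. The data shown offer no measurement that explains why trifluoromethyl differs so sharply from fluoro and chloro at this position.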